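The source may hold more compounds than are shown below. What is called first, only, known or untested is meant among the compounds shown, and "the series" means these compounds.

Working notes on the series

Compound 1 `O=C1CC[C@H](NC(=O)OCc2ccccc2)C(=O)N1` is the reference; in a functional assay on the whole organism with Mus musculus as the target (on this read-out higher numbers stand for an effect only at larger amounts of compound and lower numbers for an effect already at smaller amounts), compound 1 gives 42.5 mg/kg. Compound 2 `CN1C(=O)CC[C@H](NC(=O)OCc2ccccc2)C1=O` carries the change (methyl in place of hydrogen on an amide-type nitrogen in a ring), and in this assay compound 2 gives 12.5 mg/kg, so the step is a 3.4-fold lower number from compound 1 to compound 2 (0.53 log units; beyond the scatter).

Compound 3 `O=C1C[C@H](NC(=O)OCc2ccccc2)C(=O)N1` has a different core; the difference between the two cores is not broken down here. In this assay compound 3 gives 78.1 mg/kg, the highest of the three numbers, though its gap to compound 1 lies within the scatter, while its gap to compound 2 lies beyond it.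

Compound 4 `CN1C(=O)C[C@H](NC(=O)OCc2ccccc2)C1=O` is not yet measured. It differs from compound 3 by methyl in place of hydrogen on an amide-type nitrogen in a ring. This is the same kind of change as that from compound 1 to compound 2, but the place is not identical: there the amide-type nitrogen sits in a six-membered non-aromatic ring with 1 nitrogen, here in a five-membered non-aromatic ring with 1 nitrogen. Among the compounds with values here, because the only precedent is a 3.4-fold lower number from compound 1 to compound 2 (0.53 log units; beyond the scatter), a step of similar direction but possibly smaller size is expected, a 3.0-fold lower number from compound 3 to compound 4 (0.48 log units; beyond the scatter). In this assay compound 4 is expected to give about 26 mg/kg, estimated between 12 mg/kg and 55 mg/kg.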

Compound 4, dose for half-maximal effect: 113 mg/kg
The estimate for compound 4 lay 4.3-fold (0.64 log units) below the measured number, outside the stated range (above it).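

In this assay, methyl in place of hydrogen on an amide-type nitrogen in a ring gives a 1.4-fold higher number from compound 3 to compound 4 (0.16 log units; within the scatter), so no effect of the change can be read on this core. The step seen on the core of compound 1 therefore does not carry over to the core of compound 3, and the two steps differ: the same change on two cores in this assay, a 3.4-fold lower number (0.53 log units; beyond the scatter) from compound 1 to compound 2 and a 1.4-fold higher number (0.16 log units; within the scatter) from compound 3 to compound 4, 4.9-fold (0.69 log units) apart, beyond the scatter of two such steps. With a single pair on each core, this shows that the size of the step on one core cannot be assumed for the other in this series, but it does not show which difference between the two cores separates the steps, or how the change would behave on any further core.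

The compounds shown leave open whether an ethyl group or a longer chain in place of the methyl would split between the two cores in the same way. They also leave open whether an amine or a carboxylic acid placed elsewhere on these cores would show the same split.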